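Diaryl urea series: dichlorophenyl to dimethylphenyl swap

The source may hold more compounds than are shown below. What is called first, only, known or untested is meant among the compounds shown, and "the series" means these compounds.

Compound 1, `CC(=O)Nc1cc(NC(=O)Nc2ccc(C)c(C)c2)ccc1C`: in a functional assay on A375P cells (Homo sapiens) for antiproliferative activity (on this read-out lower numbers stand for stronger inhibition and higher numbers for weaker inhibition), compound 1 gives > 30000 nM, a limit of the assay and not a number.
Compound 2, `Cc1ccc(NC(=O)Nc2ccc(Cl)c(Cl)c2)cc1NC(=O)c1ccccc1`: in this assay compound 2 gives 5800 nM.

Among the measured compounds shown here, compound 2 holds the only measured number in the set; compound 1 sits at the limit of > 30000 nM in this assay, at which 1 of the 2 values shown sits. Compound 3, `Cc1ccc(NC(=O)Nc2ccc(C)c(NC(=O)c3ccccc3)c2)cc1C`, carries 3,4-dimethylphenyl in place of 3,4-dichlorophenyl on an amide-type nitrogen. For the measured compounds named here, no measured pair differs in this single place, so the size of the step is open. Since compound 1 also bears the dimethylphenyl group and sits at the limit of > 30000 nM in this assay, at which 1 of the 2 values shown sits, weaker inhibition is expected. For compound 3 the expected step is a 2.6-fold higher number from compound 2 to compound 3 (0.41 log units; beyond the scatter). Compound 3 is expected at 15000 nM, between 5000 nM and 45000 nM, with a real chance that only a limit is returned.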

Compound 3, half-maximal inhibitory concentration: > 30000 nM
Compound 3 ended at the assay's limit (the forecaster's own chance of this, stated with the estimate: 35%); middle value at least 2.0-fold (0.30 log units) away from the limit.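

In this assay, among the compounds shown here, 3,4-dimethylphenyl in place of 3,4-dichlorophenyl on an amide-type nitrogen gives an at least 5.1-fold higher number from compound 2 to compound 3 (0.71 log units; beyond the scatter), the first single-place reading of this change. Compound 3 returns only a limit, so the full size of the step stays unknown: the limit of > 30000 nM in this assay, at which 2 of the 3 values shown sit.

The step between compound 1 and compound 3 cannot be read, as both values are limits. Still open, as far as these compounds go, is whether a trifluoromethylphenyl or monochlorophenyl group in this place would keep the activity of compound 2, or lower its number.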